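Trifluoromethyl Replaces Tert-Butyl on the Aniline Ring

A few compounds are considered here, and "the series" means these few. Any claim that something is new, unique, unknown or untested is made for them only; others in the source may bear on it.

Within the data shown here, compound 3 `CC(C)(C)c1ccc(Nc2nc3nonc3nc2O)cc1` gives 3900 nM in an assay on mitochondria from L6 cells (Rattus norvegicus) for activation, with a stated time of 90 min (on this read-out higher numbers stand for an effect only at larger amounts of compound and lower numbers for an effect already at smaller amounts), which places it second highest of the three numbers measured so far. Compound 1 `Oc1nc2nonc2nc1Nc1ccc(SC(F)(F)F)cc1` gives 1400 nM in this assay, and compound 2 `CCc1ccc(Nc2nc3nonc3nc2O)cc1` gives 10700 nM. Both neighbouring steps, a 2.8-fold higher number from compound 1 to compound 3 (0.44 log units; beyond the scatter) and a 2.7-fold lower number from compound 2 to compound 3 (0.44 log units; beyond the scatter), are modest and beyond the scatter, while the step of a 7.6-fold higher number from compound 1 to compound 2 (0.88 log units; beyond the scatter) is the largest among the measured compounds.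

Compound 4 `Oc1nc2nonc2nc1Nc1ccc(C(F)(F)F)cc1` differs from compound 3 in one place: trifluoromethyl in place of tert-butyl on an aromatic carbon. Among the measured compounds shown here, two measured steps bear on this change. The step of a 2.8-fold higher number from compound 1 to compound 3 (0.44 log units; beyond the scatter) shows that a fluorinated group on the same aromatic carbon went with a lower number than tert-butyl, and the step of a 2.7-fold lower number from compound 2 to compound 3 (0.44 log units; beyond the scatter) shows that tert-butyl itself gave a lower number than ethyl. Because compound 1 gives 1400 nM with a group carrying three fluorines, a modest move toward a lower number is expected, though the sulfur of that group is absent in compound 4. For compound 4 the estimated value in this assay is 2500 nM, with a range from 900 nM to 7000 nM. This estimate means the step of a 1.6-fold lower number from compound 3 to compound 4 (0.19 log units; within the scatter) is expected, modest in size.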

Compound 4, half-maximal effective concentration: 10400 nM
The estimate for compound 4 lay 4.2-fold (0.62 log units) below the measured number; the measured number lies above the stated range.
By their numbers in this assay, from the lowest: compound 1; then compound 3; then compounds 4 and 2 (each within the scatter of the next).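

In this assay, trifluoromethyl in place of tert-butyl on this aromatic carbon moves the number up rather than down (a 2.7-fold higher number from compound 3 to compound 4 (0.43 log units; beyond the scatter)), so the low number of the fluorinated compound 1 does not carry over to every group with three fluorines. The step that removes only the sulfur of the (trifluoromethyl)sulfanyl group is as large as any seen so far (a 7.4-fold higher number from compound 1 to compound 4 (0.87 log units; beyond the scatter)), which ties the low number of compound 1 to the whole group rather than to its fluorines alone. Trifluoromethyl and ethyl cannot be told apart at this position (a 1.0-fold lower number from compound 2 to compound 4 (0.01 log units; within the scatter)), which leaves compound 1 and compound 3 as the two that stand clear of this pair, and no measurement shown here explains this order.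

A methylsulfanyl group would show whether sulfur without fluorine goes with a low number at this carbon, and a methoxy group, an amine or a carboxylic acid would show how far the order extends to other kinds of groups. How these groups behave on a changed core also remains open, as every compound shown shares the same one.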